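The compounds below may be only part of what the source reports. "The series", "measured", "known", "first", "only" and "open" are said of these compounds alone.

Three compounds of the series have numbers in an assay on HEK293 cells for inhibition of Voltage-dependent T-type calcium channel subunit alpha-1G (Homo sapiens), read by fluorescence, tested at 10 uM; on this read-out lower numbers stand for less inhibition and higher numbers for more inhibition at the one concentration tested (going by the name of the read-out). Compound 1 `CCCc1nc(-c2ccccc2)c(CNCCCN2CCN(c3cccc(C)c3C)CC2)o1` gives 55.2%, compound 3 `CCCc1nc(-c2ccccc2)c(CNCCCN2CCN(c3cccc(C(F)(F)F)c3)CC2)o1` gives 51.6%, and compound 2 `CCCc1nc(-c2ccccc2)c(CNCCN2CCN(c3ccccn3)CC2)o1` gives 48.1%, the lowest of the three, although its gaps to compound 3 and to compound 1 both lie within the scatter. Among the compounds with values here, the single step in which the aryl group on the ring nitrogen is exchanged, a number 3.6 percentage points lower from compound 1 to compound 3 (within the scatter), also stays within the scatter. Compound 4 `CCCc1nc(-c2ccccc2)c(CNCCN2CCN(c3ccccc3C)CC2)o1` differs from compound 2 only by 2-methylphenyl in place of pyridin-2-yl on an amine nitrogen in a ring. In this assay no step beyond the scatter is expected for this exchange because a number 3.6 percentage points lower from compound 1 to compound 3 (within the scatter) stayed within the scatter; the expected step is a number 1.9 percentage points higher from compound 2 to compound 4 (within the scatter). Compound 4 is therefore estimated at 50%, with a range from 35% to 65%.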

Compound 4, a percentage reported as inhibition, at one concentration (the size of the read-out at that concentration, not a potency): 51.3%
Compound 4: the middle estimate sits 1.3 percentage points below what was measured; the range from low to high includes it.
By their numbers in this assay, from the lowest: compounds 2, 4, 3 and 1 (each within the scatter of the next).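

In this assay the exchange gives a number 3.2 percentage points higher from compound 2 to compound 4 (within the scatter) and so stays within the scatter. The earlier step on this nitrogen joined two carbon-only aryl groups; this one removes the ring nitrogen of pyridin-2-yl and still brings no separation, so at this position the read-out does not distinguish these two rings. Nothing available bears on the reason for this.

Still open, from the compounds shown here alone, is whether a group of another kind on this nitrogen, such as a carboxylic acid or an open-chain amine, would give a step beyond the scatter.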